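This account rests on a few compounds, and the source may have more. Where it says the series, first, only, none or still open, it means among the compounds named here.

Measured in an assay on CHO cells for inhibition of sodium- and chloride-dependent glycine transporter 1 (Homo sapiens), read by scintillation counting; a higher number here means that more compound is needed for the effect, a lower number that less compound is needed:
compound 1 `C[C@H](Oc1ccc(S(C)(=O)=O)cc1C(=O)N1Cc2cc(C(F)(F)F)cnc2C1)C(F)(F)F`: 50 nM
compound 2 `C[C@H](Oc1ccc(S(C)(=O)=O)cc1C(=O)N1Cc2ccc(C3CCOCC3)cc2C1)C(F)(F)F`: 14 nM
compound 3 `CC(C)Oc1ccc(S(C)(=O)=O)cc1C(=O)N1Cc2cc(C(F)(F)F)cnc2C1`: 70 nM

Compound 2 gives the lowest number of the three; its steps to compound 1 and to compound 3 both lie beyond the scatter. Compound 1 and compound 3 share one core and differ by isopropyl in place of 1-(trifluoromethyl)ethyl on an oxygen on an aromatic ring; the step of a 1.4-fold higher number from compound 1 to compound 3 (0.15 log units; within the scatter) lies within the scatter. The difference between the core of compound 1 and the core of compound 2 is not broken down here. Compound 4 `CC(C)Oc1ccc(S(C)(=O)=O)cc1C(=O)N1Cc2ccc(C3CCOCC3)cc2C1`, not yet measured, differs from compound 2 by isopropyl in place of 1-(trifluoromethyl)ethyl on an oxygen on an aromatic ring, the same change at the same place as that from compound 1 to compound 3. For compound 4 in this assay a step of about a 1.4-fold higher number from compound 2 to compound 4 (0.15 log units; within the scatter) is expected, because a 1.4-fold higher number from compound 1 to compound 3 (0.15 log units; within the scatter) was small on the other core. The estimate for compound 4 is 20 nM, between 8 nM and 50 nM.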

Compound 4, half-maximal effective concentration in the sodium- and chloride-dependent glycine transporter 1 assay: 28 nM
Estimate against measurement, compound 4: 1.4-fold (0.15 log units) below; the range from low to high includes it.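

In the sodium- and chloride-dependent glycine transporter 1 assay, compound 2 gives 14 nM and compound 4 gives 28 nM. In the sodium- and chloride-dependent glycine transporter 1 assay, isopropyl in place of 1-(trifluoromethyl)ethyl gives a 2.0-fold higher number from compound 2 to compound 4 (0.30 log units; within the scatter), so on this second core the step again stays within the scatter. The change carries from one core to the other with no difference that the data can resolve: the same change on two cores in the sodium- and chloride-dependent glycine transporter 1 assay, a 1.4-fold higher number (0.15 log units; within the scatter) from compound 1 to compound 3 and a 2.0-fold higher number (0.30 log units; within the scatter) from compound 2 to compound 4, 1.4-fold (0.15 log units) apart, within the scatter of two such steps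

This rests on two pairs of compounds and does not show that the step would hold on any further core. In a physicochemical assay for solubility (on this read-out higher numbers stand for higher solubility and lower numbers for lower solubility), compound 2 gives 76 ug/mL and compound 4 gives 191 ug/mL. The step in the physicochemical assay, a 2.5-fold higher number from compound 2 to compound 4 (0.40 log units; beyond the scatter), is shown on one core only, so its transfer cannot be judged.

Open, from the compounds shown here alone, is how a longer chain, or a chain ending in an amine, on the same oxygen would read in these assays. Also open, going by these compounds, is the opposite stereocentre of 1-(trifluoromethyl)ethyl.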